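The compounds below may be only part of what the source reports. "The series", "measured", "known", "first", "only" and "open" are said of these compounds alone.

Of the compounds shown here, two have so far been measured in a functional assay on HeLa cells for agonist activity at 5-hydroxytryptamine receptor 6 (Homo sapiens), read by cAMP accumulation and immunoassay; on this read-out lower numbers stand for an effect already at smaller amounts and higher numbers for an effect only at larger amounts of compound. Compound 1 `O=S(=O)(c1cccc(F)c1)c1cn(C2CCNC2)c2ncccc12` gives 278 nM in this assay. Compound 2 `CN1CCC(n2cc(S(=O)(=O)c3ccccc3)c3cccnc32)C1` gives 2040 nM, the highest of the two numbers recorded; compound 1 stands at a lower number, and the gap between them lies beyond the scatter. Among the measured compounds shown here, compound 1 and compound 2 differ in more than one place, so their two values show only that compound 1 reaches its effect at a smaller amount than compound 2.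

Compound 3 `CN1CCC(n2cc(S(=O)(=O)c3cccc(F)c3)c3cccnc32)C1` has not yet been measured. It differs from compound 2 in a single place: fluoro in place of hydrogen on an aromatic carbon. For the measured compounds named here, no measured pair shows this change on its own, and compound 1, which carries the same 3-fluorophenyl, also differs from compound 2 elsewhere, so its value cannot be read as the effect of the fluoro alone. A modest step toward a lower number is expected, a 2.0-fold lower number from compound 2 to compound 3 (0.31 log units; beyond the scatter). Compound 3 is estimated at 1000 nM, with a range from 350 nM to 3000 nM.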

Compound 3, half-maximal effective concentration: 231 nM
Compound 3: middle estimate off by 4.3-fold (0.64 log units), on the high side, outside the stated range (below it).
By their numbers in this assay, from the lowest: compounds 3 and 1 (each within the scatter of the next); then compound 2.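

In this assay, the change from phenyl to 3-fluorophenyl, with fluoro in place of hydrogen on an aromatic carbon, can now be read on its own as an 8.8-fold lower number from compound 2 to compound 3 (0.95 log units; beyond the scatter), a far larger step than the single atom added might suggest. With the 3-fluorophenyl in place, methyl in place of hydrogen on the amine nitrogen in a ring gives a 1.2-fold lower number from compound 1 to compound 3 (0.08 log units; within the scatter), so in this pair the methyl does not separate the two compounds, and of the two single changes only the fluoro gives a step beyond the scatter. Nothing available explains why the fluoro step is this large.

The compounds shown leave open whether chloro, methoxy or a nitrile at the same place on the aromatic ring would give a step of similar size, or whether the step belongs to fluoro alone. They also leave open whether the fluoro step holds when the amine nitrogen carries hydrogen rather than methyl, and what an ethyl group on that nitrogen would do.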